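Turning one drawn double bond from E to Z

The source may hold more compounds than are shown below. What is called first, only, known or untested is meant among the compounds shown, and "the series" means these compounds.

This account follows a single alteration in a small set of hydroxamic acids tested for their ability to block a human enzyme. Two members of the set, compound 1 `O=C(CCCCCCNC(=O)c1ccc(-c2ccc(-c3cc(O)cc(O)c3)cc2)cc1)NO` and compound 2 `O=C(NO)c1ccc(-c2ccc(-c3cc(O)cc(O)c3)cc2)cc1`, carry no result: in an assay on isolated protein for inhibition of histone deacetylase 4 (Homo sapiens), read by fluorescence, with a stated time of 1 h (on this read-out lower numbers stand for stronger inhibition and higher numbers for weaker inhibition), compound 1 is recorded as "not determined" (no result reported), and compound 2 likewise as "not determined" (no result reported). Among the compounds with values here, that leaves compound 3 `COc1cc(/C=C/c2ccc(OC)c(NC(=O)CCCCCCC(=O)NO)c2)cc(OC)c1` as the only member with a number. In this assay compound 3 gives 9800 nM, and since nothing else in the set was measured, it stands alone and cannot be ranked against the others.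

Compound 4 `COc1cc(/C=C\c2ccc(OC)c(NC(=O)CCCCCCC(=O)NO)c2)cc(OC)c1` is its partner. Set side by side, the two structures differ as follows: the two compounds have the same atoms and bonds and differ only in configuration as drawn: 1 of 1 stereo elements differ; a double bond is drawn E in compound 3 and Z in compound 4. Within the data shown here, no pair of measured compounds shows what such a change does here, so the expectation rests on the change itself and on the one figure for compound 3.

Because compound 3 sits at 9800 nM, compound 4 is expected to remain in a similar region, with the step of a 1.1-fold higher number from compound 3 to compound 4 (0.05 log units; within the scatter) estimated to stay within the usual scatter rather than beyond it. The estimate for compound 4 in this assay is 11000 nM, with a likely range from 3500 nM to 35000 nM.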

Compound 4, half-maximal inhibitory concentration: 7600 nM
Estimate against measurement, compound 4: 1.4-fold (0.16 log units) above; low and high end bracket the measured number.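

In this assay the double bond goes from one drawn form to the other with a 1.3-fold lower number from compound 3 to compound 4 (0.11 log units; within the scatter), so the two numbers cannot be told apart from the ordinary variation between repeated measurements. Within the data shown here, until this pair, the single figure for compound 3 had nothing to be compared with, and compounds 1 and 2 could add nothing; now there is one real comparison, and it isolates a single feature: the fact that compounds 3 and 4 differ only in the configuration as drawn. For this pair, then, the drawn geometry of the double bond makes no difference that this read-out can resolve, although a single pair says nothing about double bonds in other compounds.

Compounds 1 and 2 carry no number, so they cannot be set against this pair. From the compounds shown here alone, it stays open whether the same switch would still leave the number in place with a carboxylic acid instead of the hydroxamic acid, or in a compound whose numbers lie far from those of compound 3 and compound 4.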